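Swapping a Methoxy for a Chloro on a Triazole Ester

The source may hold more compounds than are shown below. What is called first, only, known or untested is meant among the compounds shown, and "the series" means these compounds.

Of the compounds shown here, two from one series have been tested in a functional assay on A549 cells (Homo sapiens) for antiproliferative activity, read by MTT assay, with a stated time of 48 h; on this read-out higher numbers stand for weaker inhibition and lower numbers for stronger inhibition. Compound 1, with structure `C#CCOC(=O)/C(C)=C/CC/C(C)=C/CC/C(C)=C/CC[C@@H]1[C@@]2(C)CCC(=O)C(C)(C)[C@H]2CC[C@@]1(C)O`, carries a short alkyne ester on its long unsaturated chain attached to the shared core; in this assay compound 1 gives 45100 nM. Compound 2, with structure `COc1ccc(-n2cc(COC(=O)/C(C)=C/CC/C(C)=C/CC/C(C)=C/CC[C@@H]3[C@@]4(C)CCC(=O)C(C)(C)[C@H]4CC[C@@]3(C)O)nn2)cc1`, carries instead a triazole bearing a 4-methoxyphenyl group at the same position of the chain. For compound 2 this assay reports only a limit, > 150000 nM, so its value is not a number but the edge of what the assay could measure. Compound 2 therefore stands at the weak end of the two values shown, as the limit of > 150000 nM in this assay, at which 1 of the 2 values shown sits, records.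

Compound 3, with structure `C/C(=C\CC/C(C)=C/CC[C@@H]1[C@@]2(C)CCC(=O)C(C)(C)[C@H]2CC[C@@]1(C)O)CC/C=C(\C)C(=O)OCc1cn(-c2ccc(Cl)cc2)nn1`, is not yet measured. It differs from compound 2 by chloro in place of methoxy on an aromatic carbon, turning the 4-methoxyphenyl into a 4-chlorophenyl. For the measured compounds named here, no measured step between two compounds exists to guide this change, so the expectation rests on compound 2 alone. Compound 3 is expected to remain weak, with a step of about a number no higher from compound 2 to compound 3 (the limit leaves the size open), that is, no change beyond the scatter. The estimate for compound 3 in this assay is 150000 nM, within a range from 40000 nM to 500000 nM.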

Compound 3, half-maximal inhibitory concentration: > 150000 nM
Compound 3: only a limit was reported; the forecaster's own chance of this, stated with the estimate: 60%; the middle value lies on the limit itself.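

Putting chloro in place of methoxy on the aromatic ring does not bring the triazole ester back into the range that can be read in this assay: compound 3, like compound 2, is recorded only as a limit, so the step between them cannot be read. For the compounds shown here, the one step that can be read is the comparison with the short alkyne ester, which shows an at least 3.3-fold higher number from compound 1 to compound 3 (0.52 log units; beyond the scatter), so the triazole bearing a 4-chlorophenyl group goes with weaker inhibition, beyond the scatter. Compound 2 and compound 3, which carry two different groups on that aromatic ring, now both sit at the weak end of the series: the limit of > 150000 nM in this assay, at which 2 of the 3 values shown sit.

With both values given as limits, the compounds shown cannot tell whether methoxy and chloro differ at all, or how far past the limit either compound lies. From the compounds shown here alone, it also stays open whether an amine or a carboxylic acid on the same aromatic carbon would bring a triazole ester back into the range that can be read.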